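This account rests on a few compounds, and the source may have more. Where it says the series, first, only, none or still open, it means among the compounds named here.

Compound 3 `Oc1cccc(-c2cc(-c3ccccc3O)nc(-c3ccccc3O)c2)c1` carries the highest number of the three measured compounds in a functional assay on DU-145 cells (Homo sapiens) for cytotoxicity, read by CCK-8 assay, with a stated time of 4 days (on this read-out higher numbers stand for weaker inhibition and lower numbers for stronger inhibition), giving 5400 nM. Its nearest neighbour is compound 2 `Oc1cccc(-c2cc(-c3ccccc3O)cc(-c3ccccc3O)n2)c1`, which gives 3980 nM, a gap within the scatter; furthest away is compound 1 `Oc1ccc(-c2cc(-c3ccccc3O)cc(-c3ccccc3O)n2)cc1`, which gives 360 nM, a gap beyond the scatter.

The step to compound 4 `Oc1ccccc1-c1cc(-c2ccccc2O)nc(-c2ccccc2O)c1` is a rearrangement of the same atoms: 2-hydroxyphenyl in place of 3-hydroxyphenyl on an aromatic carbon. After this change all three aryl groups on the shared core of compound 3 are 2-hydroxyphenyl groups.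

Among the compounds with values here, only one measured step bears on it, and only indirectly. The move an 11-fold higher number from compound 1 to compound 2 (1.04 log units; beyond the scatter) shows that shifting the hydroxyl on the aryl group at a different place of the core has a large effect. Within the data shown here, no measured pair compares 3-hydroxyphenyl against 2-hydroxyphenyl at any place, so the direction of the present step is not fixed by the data. The pair compound 2 and compound 3 shows only that placing the 3-hydroxyphenyl at either position gives numbers within the scatter of each other.

Given that uncertainty, compound 4 is expected to land near 3000 nM, within 600 nM to 15000 nM, so that the estimated step of a 1.8-fold lower number from compound 3 to compound 4 (0.26 log units; within the scatter) is one of uncertain direction.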

Compound 4, half-maximal inhibitory concentration: 5040 nM
For compound 4 the middle estimate is 1.7-fold (0.23 log units) below the measured one; the measured number falls inside the stated range.
By their numbers in this assay, from the lowest: compound 1; then compounds 2, 4 and 3 (each within the scatter of the next).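

In this assay, 2-hydroxyphenyl in place of 3-hydroxyphenyl opposite the ring nitrogen gives a 1.1-fold lower number from compound 3 to compound 4 (0.03 log units; within the scatter), so the two groups cannot be told apart at this place. The same exchange at the other place on the core, where the earlier compounds differ, gives a 1.3-fold higher number from compound 2 to compound 4 (0.10 log units; within the scatter), whereas 2-hydroxyphenyl in place of 4-hydroxyphenyl there gives a 14-fold higher number from compound 1 to compound 4 (1.15 log units; beyond the scatter), so among these four compounds only compound 1, with its 4-hydroxyphenyl group, stands apart from the others. Nothing given here accounts for this pattern.

The compounds shown leave open whether a 4-hydroxyphenyl group opposite the ring nitrogen would give a number close to that of compound 1, as the large step is seen only at the other place on the core. They also leave open how a plain phenyl, a methoxyphenyl or an aminophenyl group would compare with the hydroxyphenyl groups at either place.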